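The compounds below may be only part of what the source reports. "The series", "measured", "known", "first", "only" and "open" are said of these compounds alone.

Measured so far, in a single screen:

Compound 1, `CC1=C(C(=O)Nc2ccc(F)cc2)C(c2ccc([N+](=O)[O-])cc2)N=C(SCc2ccccc2Cl)N1`: 18.5%
Compound 2, `CC1=C(C(=O)Nc2ccc(F)cc2)C(c2ccc([N+](=O)[O-])cc2)N=C(SCc2cccc(Cl)c2)N1`: 18.5%
Compound 3, `CC1=C(C(=O)Nc2ccc([N+](=O)[O-])cc2)C(c2cccc([N+](=O)[O-])c2)N=C(SCc2ccccc2Cl)N1`: 15.9%

All three were tested in a functional assay on the whole organism (artery, strain albino) with Rattus norvegicus as the target, with a stated time of 300 min, at a dose of 10 mg/kg by the oral route; a lower number here means less inhibition, a higher number more inhibition at the dose given (going by the name of the read-out). Compound 1 and compound 2 share a core and differ only in one group: 3-chlorophenyl in place of 2-chlorophenyl on a saturated chain carbon bound to a sulfur. This change gave no change at the digits printed from compound 1 to compound 2 (within the scatter), so the two chlorophenyl arrangements read alike in this assay. Compound 3 carries a different core; how the core of compound 3 differs from the core of compound 1 is not broken down here. In this assay compound 3 gives 15.9%, a number within the scatter of both compound 1 and compound 2.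

Compound 4, `CC1=C(C(=O)Nc2ccc([N+](=O)[O-])cc2)C(c2cccc([N+](=O)[O-])c2)N=C(SCc2cccc(Cl)c2)N1`, has not yet been measured. It relates to compound 3 exactly as compound 2 relates to compound 1: 3-chlorophenyl in place of 2-chlorophenyl on a saturated chain carbon bound to a sulfur. The place of the change is the same in both pairs, so this is the same change made on a second core.

The expectation for compound 4 rests on the measured pair: the step of no change at the digits printed from compound 1 to compound 2 (within the scatter) was flat, and the step of a number 0.1 percentage points higher from compound 3 to compound 4 (within the scatter) is estimated to be flat as well. Compound 4 is therefore expected to give about 16% in this assay, most likely between 8% and 25%.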

Compound 4, a percentage reported as inhibition, in the whole organism at one dose (the size of the read-out at that dose, not a potency): 21%
Compound 4: the middle estimate sits 5 percentage points below what was measured; the range from low to high includes it.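

In this assay the same change on the second core gives a number 5.1 percentage points higher from compound 3 to compound 4 (within the scatter) and, set beside the step on the first core, the two steps agree: the same change on two cores in this assay, no change at the digits printed (within the scatter) from compound 1 to compound 2 and a number 5.1 percentage points higher (within the scatter) from compound 3 to compound 4, 5.1 percentage points apart, within the scatter of two such steps. Within these two pairs, then, putting 3-chlorophenyl in place of 2-chlorophenyl on the saturated chain carbon bound to a sulfur carries from one core to the other without a reading that stands out from the scatter. For the compounds shown here, this does not show that the change is without effect on every core, as it rests on only two pairs, each read at one dose, and a gap hidden within the scatter cannot be ruled out.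

The compounds shown leave open whether the same flat result would hold with a plain benzyl, a methoxybenzyl or a longer alkyl chain on the sulfur. They also leave open what an amine in place of the whole sulfanyl group would do to the reading.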